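Replacing a Chlorophenyl With Thiophene on the Shared Core

The compounds below may be only part of what the source reports. "The series", "measured", "known", "first", "only" and "open" are said of these compounds alone.

Three compounds share one core and differ only in the group on a saturated ring carbon. Compound 1 `COc1cc(N2C(N)=C(C#N)C(/C=C/c3ccccc3)C3=C2CC(C)(C)CC3=O)cc(OC)c1OC` gives 30% in a functional assay on Ehrlich cells (Mus musculus) for cytotoxicity, tested at 50 ug/mL; on this read-out lower numbers stand for a weaker effect and higher numbers for a stronger effect at the one concentration tested. Compound 2 `COc1cc(N2C(N)=C(C#N)C(c3ccc(Cl)cc3Cl)C3=C2CC(C)(C)CC3=O)cc(OC)c1OC` gives 95%, and compound 3 `COc1cc(N2C(N)=C(C#N)C(c3ccccc3Cl)C3=C2CC(C)(C)CC3=O)cc(OC)c1OC` gives 20%, the lowest of the three: its gap to compound 1 lies within the scatter, whereas a number 75 percentage points lower from compound 2 to compound 3 (beyond the scatter). Compound 4 `COc1cc(N2C(N)=C(C#N)C(c3cccs3)C3=C2CC(C)(C)CC3=O)cc(OC)c1OC` carries thiophen-2-yl in place of 2-chlorophenyl on a saturated ring carbon. Among the compounds with values here, no measured step exchanges one aromatic ring for another of a different kind; the known steps are a number 65 percentage points higher from compound 1 to compound 2 (beyond the scatter) and a number 10 percentage points lower from compound 1 to compound 3 (within the scatter), and neither matches this change. Without a matching step, no change beyond the scatter is expected, so the estimate is a number 10 percentage points higher from compound 3 to compound 4 (within the scatter). Compound 4 is therefore estimated at 30%, between 10% and 70%.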

Compound 4, a percentage reported as activity, at one concentration (the size of the read-out at that concentration, not a potency): 15%
Beside the measured number, compound 4's estimate is 15 percentage points above it, within the range that was stated.
By their numbers in this assay, from the lowest: compounds 4, 3 and 1 (each within the scatter of the next, the first and the last beyond it); then compound 2.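

In this assay, thiophen-2-yl, a five-membered aromatic ring with one sulfur atom, can take the place of 2-chlorophenyl on this saturated ring carbon with no difference beyond the scatter (a number 5 percentage points lower from compound 3 to compound 4 (within the scatter)). It does not reach the level of the 2,4-dichlorophenyl group (a number 80 percentage points lower from compound 2 to compound 4 (beyond the scatter)), and it also stands apart from 2-phenylethenyl (a number 15 percentage points lower from compound 1 to compound 4 (beyond the scatter)). Nothing available explains these differences.

Still open, on these data alone, is whether a chloro group on the thiophene ring would give a high number, as the second chloro does in compound 2. As far as these compounds go, how a furan-2-yl or pyridin-2-yl ring would behave at this position also remains unknown.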